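A few compounds are considered here, and "the series" means these few. Any claim that something is new, unique, unknown or untested is made for them only; others in the source may bear on it.

In an ADME assay on MRC5 cells (Homo sapiens) for cytotoxicity, read by neutral red uptake, with a stated time of 24 h (a lower number here means a stronger inhibitor, a higher number a weaker inhibitor), compound 1 `CC(=O)Oc1c(C(C)C)cc2c3c1OC(=O)[C@@]31CCCC(C)(C)[C@@H]1CC2` gives 290000 nM, compound 2 `CC(C)c1cc2c3c(c1OC(=O)CCl)OC(=O)[C@@]31CCCC(C)(C)[C@@H]1CC2` gives 130000 nM and compound 3 `CC(C)C(=O)Oc1c(C(C)C)cc2c3c1OC(=O)[C@@]31CCCC(C)(C)[C@@H]1CC2` gives 119000 nM. Compound 3 thus stands level with compound 2 within the scatter, and both lie under compound 1. Compound 4 `CCC(=O)Oc1c(C(C)C)cc2c3c1OC(=O)[C@@]31CCCC(C)(C)[C@@H]1CC2` differs from compound 3 by hydrogen in place of methyl on a saturated chain carbon bound to a carbonyl carbon and a saturated chain carbon: hydrogen in place of methyl, turning isopropyl into ethyl. The nearest evidence is a 2.4-fold lower number from compound 1 to compound 3 (0.39 log units; beyond the scatter), a modest step for isopropyl in place of methyl on a carbonyl carbon. a 1.1-fold lower number from compound 2 to compound 3 (0.04 log units; within the scatter) adds little, and a 2.2-fold lower number from compound 1 to compound 2 (0.35 log units; beyond the scatter) is also modest. Ethyl falls short of that full change, so only part of the way back is expected: a 1.5-fold higher number from compound 3 to compound 4 (0.18 log units; within the scatter), upward and small. For compound 4 the estimated value is 180000 nM, with an expected range of 110000 nM to 300000 nM.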

Compound 4, half-maximal inhibitory concentration: 125000 nM
The estimate for compound 4 lay 1.4-fold (0.16 log units) above the measured number; low and high end bracket the measured number.
By their numbers in this assay, from the lowest: compounds 3, 4 and 2 (each within the scatter of the next); then compound 1.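

In this assay, cutting isopropyl to ethyl at the saturated chain carbon bound to a carbonyl carbon gives no readable change (a 1.1-fold higher number from compound 3 to compound 4 (0.02 log units; within the scatter)), and methyl in place of chloro at that carbon gives none either (a 1.0-fold lower number from compound 2 to compound 4 (0.02 log units; within the scatter)). Only compound 1 stands apart (a 2.3-fold lower number from compound 1 to compound 4 (0.37 log units; beyond the scatter)), so among these compounds a single methyl in place of hydrogen at this carbon carries the modest shift, and the further methyl of compound 3 adds nothing readable. No measured data here explain this flat stretch.

On these data alone, whether a longer chain, an amine or a carboxylic acid at this carbon would stay level with compounds 2, 3 and 4 remains open.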